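Amino in place of nitro in the series

This account rests on a few compounds, and the source may have more. Where it says the series, first, only, none or still open, it means among the compounds named here.

Among the measured compounds shown here, in a functional assay on SGC-7901 cells (Homo sapiens) for antiproliferative activity, read by MTT assay, with a stated time of 72 h (on this read-out lower numbers stand for stronger inhibition and higher numbers for weaker inhibition), compound 2 `COc1ccc(-c2ssc(=O)c2-c2cc(OC)c(OC)c(OC)c2)cc1[N+](=O)[O-]` gives 440 nM, the lower of the two numbers so far, while compound 1 `COc1ccc(-c2ssc(=O)c2-c2cc(OC)c(OC)c(OC)c2)cc1O` gives 3110 nM. Compound 3 `COc1ccc(-c2ssc(=O)c2-c2cc(OC)c(OC)c(OC)c2)cc1N` carries amino in place of nitro on an aromatic carbon, ortho to a methoxy group: amino in place of nitro on an aromatic carbon. For the measured compounds named here, only one measured step bears on this place, a 7.1-fold lower number from compound 1 to compound 2 (0.85 log units; beyond the scatter), nitro in place of hydroxy, and no amino compound has a number yet. That step sets no firm direction for amino, so no change beyond the scatter is expected. The expected step is a 1.5-fold lower number from compound 2 to compound 3 (0.17 log units; within the scatter). For compound 3 the estimated value is 300 nM, with a range of 40 nM to 2500 nM.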

Compound 3, half-maximal inhibitory concentration: 172 nM
Beside the measured number, compound 3's estimate is 1.7-fold (0.24 log units) above it; the range from low to high includes it.
By their numbers in this assay, from the lowest: compound 3; then compound 2; then compound 1.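

Amino in place of nitro, ortho to a methoxy group, gives in this assay a 2.6-fold lower number from compound 2 to compound 3 (0.41 log units; beyond the scatter) and so the stronger inhibition at this place does not belong to nitro alone. Set against hydroxy, amino shows an 18-fold lower number from compound 1 to compound 3 (1.26 log units; beyond the scatter) and the order at this place now runs amino, then nitro, then hydroxy. Nothing available here gives a reason for that order.

As far as these compounds go, whether a methylamino group, an acetamide or a carboxylic acid at this place would continue that order stays open. So does whether the order holds on other cell lines.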